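Acyl variation across a shared amide core

This account rests on a few compounds, and the source may have more. Where it says the series, first, only, none or still open, it means among the compounds named here.

Measured compounds:
compound 1, `COc1ccc(CN(C(=O)C=C(C)C)c2cc(OC)c(OC)c(OC)c2)cc1O`, 320 nM
compound 2, `C=C(C)C(=O)N(Cc1ccc(OC)c(O)c1)c1cc(OC)c(OC)c(OC)c1`, 390 nM
compound 3, `COc1ccc(CN(C(=O)CO)c2cc(OC)c(OC)c(OC)c2)cc1O`, 160 nM

In a functional assay on MGC-803 cells (Homo sapiens) for inhibition, read by MTT assay, with a stated time of 48 h (a higher number here means a weaker inhibitor, a lower number a stronger inhibitor), compound 3 gives the lowest of the three numbers. Its nearest neighbour is compound 1, reached by a 2.0-fold lower number from compound 1 to compound 3 (0.30 log units; within the scatter), a step within the scatter, so the two cannot be ordered. The step of a 2.4-fold lower number from compound 2 to compound 3 (0.39 log units; beyond the scatter) is modest but beyond the scatter, and a 1.2-fold higher number from compound 1 to compound 2 (0.09 log units; within the scatter) is within it. All three steps change only the group on the carbonyl carbon, and none moves the number far.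

Compound 4, `CCC(=O)N(Cc1ccc(OC)c(O)c1)c1cc(OC)c(OC)c(OC)c1`, differs from compound 3 by methyl in place of hydroxy on a saturated chain carbon bound to a carbonyl carbon. Among the compounds with values here, no measured pair removes a hydroxy from a saturated chain carbon, so the expectation rests on the general finding that acyl changes in this set gave steps of at most the size of a 2.4-fold lower number from compound 2 to compound 3 (0.39 log units; beyond the scatter). Compound 3 carries the only hydroxy on the acyl group and also the lowest number, so removing it may raise the number somewhat. Compound 4 is therefore expected to show a 1.6-fold higher number from compound 3 to compound 4 (0.21 log units; within the scatter), a small change within or near the scatter. The estimate for compound 4 in this assay is 260 nM, with a range from 120 nM to 560 nM.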

Compound 4, half-maximal inhibitory concentration: 50 nM
Compound 4: middle estimate off by 5.2-fold (0.72 log units), on the high side, and the stated range ends above it.
By their numbers in this assay, from the lowest: compound 4; then compounds 3, 1 and 2 (each within the scatter of the next, the first and the last beyond it).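

In this assay, methyl in place of hydroxy on a saturated chain carbon bound to a carbonyl carbon gives a 3.2-fold lower number from compound 3 to compound 4 (0.51 log units; beyond the scatter), so the acyl hydroxy is not required for a low number, and the change runs opposite to the rise expected on its removal. Ethyl on the carbonyl carbon also separates from both unsaturated groups, with a 7.8-fold lower number from compound 2 to compound 4 (0.89 log units; beyond the scatter) and a 6.4-fold lower number from compound 1 to compound 4 (0.81 log units; beyond the scatter), and these are larger than any step among the earlier compounds, so this position tolerates less variation than those compounds suggested. No available evidence accounts for these steps.

Only one saturated acyl group without a hydroxy is shown here, so it remains open whether the low number depends on ethyl itself. Open too, as far as these compounds go, is how a longer chain such as propyl, or an amine or methoxy on the same chain carbon, would read.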